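Piperidinyl substitution at the aminopyridine position of the amide series

The source may report more compounds than this note shows. Statements on the series, on what has been measured and on what is new or still open speak of the compounds shown alone.

Compound 1 `Cc1ccc(Cl)cc1Nc1nc(C(F)(F)F)ccc1CNC(=O)C(C)c1ccc(NS(C)(=O)=O)c(F)c1`, compound 2 `CC(C(=O)NCc1ccc(C(F)(F)F)nc1NCc1cccnc1)c1ccc(NS(C)(=O)=O)c(F)c1` and compound 3 `CC(C(=O)NCc1ccc(C(F)(F)F)nc1N1CCC(Cc2ccc(F)c(F)c2)CC1)c1ccc(NS(C)(=O)=O)c(F)c1` share the same amide core and differ only in the group on the aromatic carbon next to the ring nitrogen. In a functional assay on CHO-K1 cells for antagonist activity at transient receptor potential cation channel subfamily V member 1 (Homo sapiens), read by FLIPR (on this read-out higher numbers stand for weaker inhibition and lower numbers for stronger inhibition), compound 1 gives 14 nM, and compound 3 gives 0.2 nM. For compound 2 this assay reports "not active" (no number reported), so no single number stands for it and its place on the scale cannot be fixed. Compound 4 `COC1CCN(c2nc(C(F)(F)F)ccc2CNC(=O)C(C)c2ccc(NS(C)(=O)=O)c(F)c2)CC1` has not been measured. It differs from compound 2 by 4-methoxypiperidin-1-yl in place of ((pyridin-3-yl)methyl)amino on an aromatic carbon. The change puts a piperidin-1-yl group in the place where compound 3 carries its piperidin-1-yl group, while compound 2, which carries ((pyridin-3-yl)methyl)amino there, has no number at all. Among the compounds with values here, since no step between measured compounds is known for this change, the size of the move for compound 4 can only be expected: a gain in this assay, from not active to a measurable number, is the working expectation. Compound 3 with its piperidin-1-yl reaches 0.2 nM, which supports the direction. Compound 4 is estimated at 40 nM, with a range from 4 nM to 400 nM.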

Compound 4, inhibition constant: 2.4 nM
Estimate against measurement, compound 4: 17-fold (1.22 log units) above, and the stated range ends above it.
By their numbers in this assay, from the lowest: compound 3; then compound 4; then compound 1.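

Compound 4, with 4-methoxypiperidin-1-yl on this aromatic carbon, gives 2.4 nM in this assay, so a group of the same heavy-atom count as the ((pyridin-3-yl)methyl)amino of compound 2 can give a measurable number here; the step from compound 2 cannot be read as a size, since compound 2 has no number. Compound 4 also shows that this position needs neither an aromatic ring nor a hydrogen-bond donor in its substituent for a low-nanomolar value, with a 5.8-fold lower number from compound 1 to compound 4 (0.77 log units; beyond the scatter) on replacing (5-chloro-2-methylphenyl)amino. The substituent on the piperidine still counts, as the change from 3,4-difluorobenzyl to methoxy gives a 12-fold higher number from compound 3 to compound 4 (1.08 log units; beyond the scatter).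

Between compound 2 and compound 4 the ring type and the hydrogen-bond donor change together, so these compounds do not separate the two, and it remains open how a hydroxyl, an ethoxy or an unsubstituted benzyl on the piperidine would read. No measurement at hand explains the differences among these substituents.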